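This account rests on a few compounds, and the source may have more. Where it says the series, first, only, none or still open, it means among the compounds named here.

Measured compounds:
compound 1, `COc1cc(OC)c(-c2coc3cc(OCc4ccc(F)cc4)ccc3c2=O)cc1OC`, 1120 nM
compound 2, `COc1cc(OC)c(-c2coc3cc(OCc4cccc(Cl)c4)ccc3c2=O)cc1OC`, 2280 nM

Both were tested in a functional assay on B16 cells (Mus musculus) for antiproliferative activity, read by MTT assay, with a stated time of 24 h; on this read-out lower numbers stand for stronger inhibition and higher numbers for weaker inhibition. Among the compounds with values here, on this read-out compound 1 gives 1120 nM, the lowest of the two numbers; the only other measured compound, compound 2, gives 2280 nM, and the step is a 2.0-fold higher number from compound 1 to compound 2 (0.31 log units; beyond the scatter).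

The unmeasured compound 3, `COc1cc(OC)c(-c2coc3cc(OCc4cccc(C(F)(F)F)c4)ccc3c2=O)cc1OC`, shares the core of compound 1 and differs from it only at the group hanging off the side chain: 3-(trifluoromethyl)phenyl in place of 4-fluorophenyl on a saturated chain carbon bound to an oxygen on an aromatic ring. In words, a 3-(trifluoromethyl)benzyl replaces the 4-fluorobenzyl.

Within the data shown here, the one measured step that bears on this is the one from compound 1 to compound 2, where a 3-chlorophenyl likewise replaced the 4-fluorophenyl at the same place, and the number rose modestly. Compound 3 carries a different substituent on that ring, so the comparison is loose, but the direction of that step is the best guide available. A modest increase in the number is therefore expected, with wide uncertainty. For compound 3 the expected step is a 1.8-fold higher number from compound 1 to compound 3 (0.25 log units; within the scatter), giving an estimate of 2000 nM with a range from 900 nM to 4500 nM.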

Compound 3, half-maximal inhibitory concentration: > 10000 nM
Compound 3 gave a limit, no number (the forecaster's own chance of this, stated with the estimate: 5%); middle value at least 5.0-fold (0.69 log units) away from the limit.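

In this assay, the result for compound 3 is a limit and not a number: the limit of > 10000 nM in this assay, at which 1 of the 3 values shown sits. Even as a minimum, the change at this position is large: the replacement of 4-fluorobenzyl by 3-(trifluoromethyl)benzyl gives an at least 8.9-fold higher number from compound 1 to compound 3 (0.95 log units; beyond the scatter), whereas the only earlier step was a 2.0-fold higher number from compound 1 to compound 2 (0.31 log units; beyond the scatter). The swap of trifluoromethyl in place of chloro on an aromatic carbon gives an at least 4.3-fold higher number from compound 2 to compound 3 (0.64 log units; beyond the scatter), which shows something the first two compounds could not: with the rest of the molecule unchanged, the choice of this one ring substituent can separate a compound with a measurable number in this cell assay from one that reaches the limit.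

The compounds shown leave open how a methyl, a methoxy or an amine on this ring would behave, and whether a longer chain could take the place of the ring altogether. As far as these compounds go, with a limit in place of a number for compound 3, the true size of both new steps also remains unknown.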